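This account rests on a few compounds, and the source may have more. Where it says the series, first, only, none or still open, it means among the compounds named here.

Working notes on the series. Compound 1 `Cc1nn(C)c2c1C(c1ccccc1)=NCCN2C` gives 2.5 mg/kg in a functional assay on the whole organism for positive allosteric modulation, with Rattus norvegicus as the target; a lower number here means that less compound is needed, a higher number that more compound is needed for the effect. Compound 2 `Cc1nn(C)c2c1C(c1ccccc1Cl)=NCCN2C` gives 2.5 mg/kg in this assay, and compound 3 `Cc1nn(C)c2c1C(c1ccc(Cl)c(Cl)c1)=NCCN2` gives 2.5 mg/kg in this assay. Compound 2 and compound 1 differ in one place: hydrogen in place of chloro on an aromatic carbon. The step of no change at the digits printed from compound 2 to compound 1 (within the scatter). The difference between the core of compound 2 and the core of compound 3 is not broken down here; the two values in this assay simply lie level. Compound 4 `Cc1nn(C)c2c1C(c1ccc(Cl)cc1)=NCCN2` is not yet measured and differs from compound 3 by hydrogen in place of chloro on an aromatic carbon. This is the same kind of change as that from compound 2 to compound 1, not the same: in compound 2 the chloro that leaves sits ortho to a large group, in compound 3 it sits ortho to a chloro group (1 heavy atom) and meta to a large group. Because no change at the digits printed from compound 2 to compound 1 (within the scatter) is within the scatter, the expected step is no change at the digits printed from compound 3 to compound 4 (within the scatter). Compound 4 is expected to give 2.5 mg/kg in this assay, with a likely range from 1.2 mg/kg to 5 mg/kg.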

Compound 4, minimum effective dose: 2.5 mg/kg
Estimate against measurement, compound 4: no gap at the digits printed; low and high end bracket the measured number.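

Replacing chloro with hydrogen on an aromatic carbon gives, in this assay, no change at the digits printed from compound 3 to compound 4 (within the scatter), and this step agrees with the one on the other core, no change at the digits printed from compound 2 to compound 1 (within the scatter), as the comparison shows: the same change on two cores in this assay, no change at the digits printed (within the scatter) from compound 2 to compound 1 and no change at the digits printed (within the scatter) from compound 3 to compound 4, 1.0-fold (0.00 log units) apart, within the scatter of two such steps. On these two pairs, then, the change carries from one core to the other without a difference that can be told from the scatter, including where the chloro that leaves sits ortho to a chloro group and meta to a large group. This does not show that a step of real size would carry over in the same way, since neither step rises above the scatter, and two pairs say nothing about the change on other cores in the series.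

The compounds shown leave open whether a different group on the aromatic ring, such as an amine or a carboxylic acid, would shift the dose in this assay. They also leave open whether a longer chain in place of a methyl group on the core would do so.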